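Swapping Isopropyl for Bromo at the Amide-Bearing Ring

The compounds below may be only part of what the source reports. "The series", "measured", "known", "first", "only" and "open" are said of these compounds alone.

Of the compounds shown here, two built on one shared core have so far been tested in an assay on isolated protein for inhibition of aldehyde dehydrogenase 1A1 (Homo sapiens), read by spectrophotometry, tested at 10 uM; on this read-out higher numbers stand for more inhibition at the one concentration tested (going by the name of the read-out) and lower numbers for less inhibition. Compound 1 `Cc1cccc(Cn2c(CN3CCN(C(=O)c4ccc(C(C)C)cc4)CC3)nc3ccccc32)c1` gives 67.6% and stands highest of the two numbers. Compound 2 `O=C(C1CC1)N1CCN(Cc2nc3ccccc3n2Cc2ccc(C(F)(F)F)cc2)CC1` gives 37%, a result lower than that of compound 1 by more than the usual scatter; the two differ in more than one place, so that gap cannot be tied to any single change.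

Compound 3 `Cc1cccc(Cn2c(CN3CCN(C(=O)c4ccc(Br)cc4)CC3)nc3ccccc32)c1` has not been measured. It differs from compound 1 in one place: bromo in place of isopropyl on an aromatic carbon. Within the data shown here, no measured pair shows this change, so its effect has no precedent here. A small step downward from compound 1 to compound 3 is expected, a number 12.6 percentage points lower from compound 1 to compound 3 (beyond the scatter), which may well fall within the scatter. For compound 3 an inhibition of 55% is estimated, with a range from 30% to 75%.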

Compound 3, a percentage reported as inhibition, at one concentration (the size of the read-out at that concentration, not a potency): 25.8%
The estimate for compound 3 lay 29.2 percentage points above the measured number, and the stated range ends above it.
By their numbers in this assay, from the lowest: compound 3; then compound 2; then compound 1.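

In this assay, among these compounds, exchanging isopropyl for bromo on the aromatic ring of the amide gives a number 41.8 percentage points lower from compound 1 to compound 3 (beyond the scatter) with the rest of the molecule unchanged, which is the first effect here that can be tied to one place. This position therefore matters: going from 4-isopropylphenyl to 4-bromophenyl, a group of three carbons replaced by a single bromine, is enough to lose much of the inhibition seen with compound 1. Nothing available explains why the number falls this far.

As far as these compounds go, with only these two groups compared at this position, it remains open whether a longer chain such as butyl, a tert-butyl group, or a methoxy group would restore inhibition. It is also unclear how an amine or a carboxylic acid would behave there.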